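Lengthening the Chain of Compound 3

The source may hold more compounds than are shown below. What is called first, only, known or untested is meant among the compounds shown, and "the series" means these compounds.

In an ADME assay on microsomes from liver (Mus musculus) for metabolic stability, read by LC-MS, with a stated time of 10 min, tested at 0.5 uM (on this read-out lower numbers stand for a less stable compound and higher numbers for a more stable compound), compound 3 `c1ccc2c(c1)CN[C@@H](CN(CCN1CCNCC1)[C@H]1CCCc3cccnc31)C2` stands highest of the three measured compounds at 79%, ahead of compound 2 `CC(C)N1CCN(CCCN(C[C@H]2Cc3ccccc3CN2)[C@H]2CCCc3cccnc32)CC1` at 58% and compound 1 `c1ccc2c(c1)CN[C@@H](CN(CCC1CCNCC1)[C@H]1CCCc3cccnc31)C2` at 32%. Compound 4 `c1ccc2c(c1)CN[C@@H](CN(CCCCN1CCNCC1)[C@H]1CCCc3cccnc31)C2` differs from compound 3 by 2-(piperazin-1-yl)ethyl in place of piperazin-1-yl on a saturated chain carbon, two bonds along the chain from an amine nitrogen.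

For the measured compounds named here, no measured step makes exactly this change. The closest is a number 21 percentage points higher from compound 2 to compound 3 (beyond the scatter), a modest step, with piperazin-1-yl in place of (4-isopropylpiperazin-1-yl)methyl. It also removes the isopropyl group, so it cannot be read for chain length alone. The large step of a number 47 percentage points higher from compound 1 to compound 3 (beyond the scatter) replaces piperidin-4-yl with piperazin-1-yl and says little about chain length.

On the evidence of a number 21 percentage points higher from compound 2 to compound 3 (beyond the scatter) read in reverse, a modest drop is expected in this assay, though a result within the scatter of compound 3 remains possible. The expected change is a number 19 percentage points lower from compound 3 to compound 4 (beyond the scatter). The estimated value for compound 4 is 60%, with an expected range of 40% to 78%.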

Compound 4, percent of the compound remaining: 96%
Estimate against measurement, compound 4: 36 percentage points below, outside the stated range (above it).
By their numbers in this assay, from the lowest: compound 1; then compound 2; then compound 3; then compound 4.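

In this assay, for the compounds shown here, the step to 2-(piperazin-1-yl)ethyl in place of piperazin-1-yl gives a number 17 percentage points higher from compound 3 to compound 4 (beyond the scatter) and, with the piperazine ring itself unchanged, is the first reading of chain lengthening alone at this position, on a saturated chain carbon, two bonds along the chain from an amine nitrogen. Compound 4 now stands highest of the four, with a number 38 percentage points higher from compound 2 to compound 4 (beyond the scatter) for (piperazin-1-yl)methyl in place of 4-isopropylpiperazin-1-yl and a number 64 percentage points higher from compound 1 to compound 4 (beyond the scatter) for 2-(piperazin-1-yl)ethyl in place of piperidin-4-yl, so the longer chain does not carry the loss that the step between compound 2 and compound 3 had suggested. Nothing available explains why lengthening the chain goes with a higher number in this read-out.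

The compounds shown leave open whether a still longer chain, such as 3-(piperazin-1-yl)propyl, would hold this level. They also leave open how an isopropyl group on the piperazine, or a morpholine in place of that ring, would read on the chain of compound 4.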